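Halobenzyl series: swapping ring position and halogen

A few compounds are considered here, and "the series" means these few. Any claim that something is new, unique, unknown or untested is made for them only; others in the source may bear on it.

Three measured compounds share one core and differ only in the bromophenyl on a saturated chain carbon bound to an aromatic nitrogen. In a functional assay on MIA PaCa-2 cells (Homo sapiens) for inhibition, read by MTT assay, with a stated time of 48 h, tested at 10 uM (on this read-out higher numbers stand for more inhibition of growth at the one concentration tested and lower numbers for less inhibition of growth), compound 1 `O=C(/C=C/c1ccc(OCc2cn(Cc3ccccc3Br)nn2)cc1)c1ccc([N+](=O)[O-])cc1` gives 34%. Compound 2 `O=C(/C=C/c1ccc(OCc2cn(Cc3cccc(Br)c3)nn2)cc1)c1ccc([N+](=O)[O-])cc1` gives 21%, and compound 3 `O=C(/C=C/c1ccc(OCc2cn(Cc3ccc(Br)cc3)nn2)cc1)c1ccc([N+](=O)[O-])cc1` gives 17%. Compound 3 holds the lowest of the three numbers; its gap to compound 2 lies within the scatter, while the step of a number 17 percentage points lower from compound 1 to compound 3 (beyond the scatter) lies beyond it, as does a number 13 percentage points lower from compound 1 to compound 2 (beyond the scatter).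

Compound 4 `O=C(/C=C/c1ccc(OCc2cn(Cc3ccccc3F)nn2)cc1)c1ccc([N+](=O)[O-])cc1` is not yet measured. It differs from compound 3 by 2-fluorophenyl in place of 4-bromophenyl on a saturated chain carbon bound to an aromatic nitrogen. Two things change at once: where the halogen sits on the ring and which halogen it is. Only the first has a measured precedent, the step of a number 17 percentage points lower from compound 1 to compound 3 (beyond the scatter) read in reverse, which would point upward by a modest amount. Within the data shown here, no measured step covers the exchange of bromine for fluorine, so that part is open. A modest rise is therefore expected for compound 4, about a number 13 percentage points higher from compound 3 to compound 4 (beyond the scatter). The estimate for compound 4 in this assay is 30%, within a range from 15% to 45%.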

Compound 4, percent growth inhibition at one concentration: 22%
Beside the measured number, compound 4's estimate is 8 percentage points above it, within the range that was stated.
By their numbers in this assay, from the lowest: compounds 3, 2 and 4 (each within the scatter of the next); then compound 1.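

Exchanging the halogen alone, fluoro in place of bromo on an aromatic carbon, gives a number 12 percentage points lower from compound 1 to compound 4 (beyond the scatter) in this assay, so the higher number of compound 1 depends on the halogen as well as on where it sits. The fluoro compound does not separate from the other two bromo compounds, with a number 5 percentage points higher from compound 3 to compound 4 (within the scatter) and a number 1 percentage points higher from compound 2 to compound 4 (within the scatter), and among these four compounds only compound 1 stands apart. Nothing at hand bears on why bromine at that ring position gives the higher number.

Fluoro at the ring placements of the bromine in compound 2 and compound 3 remains open, so it cannot be said whether ring placement counts at all with fluorine. Equally open, from the compounds shown here alone, is whether a chloro or a methoxy group in place of the halogen of compound 1 would hold the higher number.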